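Compound 3 to compound 4: a trifluoromethyl swap

The source may report more compounds than this note shows. Statements on the series, on what has been measured and on what is new or still open speak of the compounds shown alone.

Of the compounds shown here, three sharing one core have been measured in a physicochemical assay for solubility, in phosphate buffer, with a stated time of 18 h, at pH 7.4; a higher number here means a more soluble compound, a lower number a less soluble compound. Compound 1 (`CCN(CC)C(=O)COc1cc2c(-n3nc(-c4ccccn4)nc3N)ncnc2cc1OC`) gives 42000 nM, and compound 2 (`COc1cc2ncnc(-n3nc(-c4ccccn4)nc3N)c2cc1OCCCNC(=O)CN1C[C@@H](C)O[C@@H](C)C1`) gives 34000 nM. Compound 3 (`COc1cc2ncnc(-n3nc(-c4ccccn4)nc3N)c2cc1OCCCNC(=O)OCC(F)(F)F`) gives 100 nM, the lowest of the three numbers.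

Compound 4 (`COc1cc2ncnc(-n3nc(-c4ccccn4)nc3N)c2cc1OCCCNC(=O)OCC(C)(C)C`) departs from compound 3 in one place, with tert-butyl in place of trifluoromethyl on a saturated chain carbon bound to an oxygen next to a carbonyl group. The same difference reads as 2,2,2-trifluoroethoxy to neopentyloxy.

Two measured steps end at compound 3, and both are large: a 420-fold lower number from compound 1 to compound 3 (2.62 log units; beyond the scatter), and a 340-fold lower number from compound 2 to compound 3 (2.53 log units; beyond the scatter). Both bring in the 2,2,2-trifluoroethoxy group, but neither exchanges trifluoromethyl for tert-butyl, so the data hold no direct measure of this swap. Those steps replaced far more of the side chain than the present change does, so a step of their size is not expected here. Since compound 3 stands at 100 nM, only a slight move to a lower number is expected in this assay.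

The estimate amounts to a 1.7-fold lower number from compound 3 to compound 4 (0.22 log units; within the scatter), which is expected to stay modest. Compound 4 is estimated at 60 nM, with an expected range of 15 nM to 300 nM.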

Compound 4, solubility: 200 nM
Compound 4: middle estimate off by 3.3-fold (0.52 log units), on the low side, within the range that was stated.
By their numbers in this assay, from the lowest: compounds 3 and 4 (each within the scatter of the next); then compounds 2 and 1 (each within the scatter of the next).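

In this assay, going by these compounds alone, the exchange of trifluoromethyl for tert-butyl on a saturated chain carbon bound to an oxygen next to a carbonyl group gives a 2.0-fold higher number from compound 3 to compound 4 (0.30 log units; within the scatter) and is the first direct reading of this swap, which leaves the two groups indistinguishable at this position. The large drop seen with the 2,2,2-trifluoroethoxy group recurs with neopentyloxy: replacing (2,6-dimethylmorpholin-4-yl)methyl on a carbonyl carbon gives a 170-fold lower number from compound 2 to compound 4 (2.23 log units; beyond the scatter) and replacing diethylcarbamoyl with 2-((neopentyloxycarbonyl)amino)ethyl gives a 210-fold lower number from compound 1 to compound 4 (2.32 log units; beyond the scatter) as the second large step to compound 4, so the drop does not depend on the fluorine atoms of compound 3. Nothing measured here accounts for these numbers.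

The compounds shown leave open whether a dimethylamino group or a carboxylic acid at this same chain end would stay close to compound 3 and compound 4 or move toward compound 1 and compound 2. They also leave open how a longer chain between the core oxygen and the carbonyl would read in this assay with either trifluoromethyl or tert-butyl in place.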